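The compounds below may be only part of what the source reports. "The series", "measured", "known", "first", "only" and "open" are said of these compounds alone.

Of the compounds shown here, two sharing one core have been tested in a functional assay on SGC-7901 cells (Homo sapiens) for antiproliferative activity, read by sulforhodamine B assay, with a stated time of 72 h; a lower number here means a stronger inhibitor, a higher number a weaker inhibitor. Compound 1 `COc1ccc(C)cc1NC(=S)N/N=C/c1ccc2ccccc2n1` reaches only a limit there, > 100000 nM, so no number is known for it. Among the compounds with values here, compound 2 `Fc1cccc(NC(=S)N/N=C/c2ccc3ccccc3n2)c1` is the one compound for which this assay gives a measured number, 79900 nM. Of the two entries, that number stands alone; the other entry is the limit of > 100000 nM in this assay, at which 1 of the 2 values shown sits. Within the data shown here, compound 2 is therefore a weak inhibitor, yet the only one placed by a number.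

Compound 3 `Cc1ccccc1NC(=S)N/N=C/c1ccc2ccccc2n1` has not been measured in this assay. Compared with compound 2 it differs in one place: 2-methylphenyl in place of 3-fluorophenyl on an amide-type nitrogen. Among the measured compounds shown here, no pair of measured compounds shows what such a swap on that nitrogen does, so there is no measured step to lean on. The change is small in size, and no shift beyond the usual scatter is expected: the step from compound 2 to compound 3 is estimated as a 1.1-fold higher number from compound 2 to compound 3 (0.03 log units; within the scatter). Compound 3 is thus expected to sit near 85000 nM, within a range from 35000 nM to 200000 nM, with a fair chance that this assay returns only a limit for it.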

Compound 3, half-maximal inhibitory concentration: > 100000 nM
Compound 3 gave a limit, no number; the forecaster's own chance of this, stated with the estimate: 40%; middle value at least 1.1-fold (0.07 log units) from the limit.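

Within the data shown here, replacing 3-fluorophenyl with 2-methylphenyl on the amide-type nitrogen gives the first measured step at this position, an at least 1.2-fold higher number from compound 2 to compound 3 (0.09 log units; that floor lies within the scatter). Compound 3 returns only a limit, so this step is a floor and not a full measurement: the true change could be negligible or much larger. What the swap does show is that this new group on that nitrogen does not bring the compound into the range where this assay gives a number, and the compounds now cluster at the edge of that range: the limit of > 100000 nM in this assay, at which 2 of the 3 values shown sit.

As far as these compounds go, how far compound 3 lies past its limit remains unknown, and this single swap cannot separate the loss of the fluorine from the gain of the methyl group, since both change at once. Also open, from the compounds shown here alone, is whether a clearly lower number in this assay could come from a different group on that nitrogen, such as a benzyl group or a longer alkyl chain in place of the substituted phenyl ring, or from an amine or a carboxylic acid carried on that ring.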